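Replacing the side chain of compound 2

The source may hold more compounds than are shown below. What is called first, only, known or untested is meant among the compounds shown, and "the series" means these compounds.

In a functional assay on A549 cells (Homo sapiens) for inhibition, read by sulforhodamine B assay, with a stated time of 72 h (on this read-out lower numbers stand for stronger inhibition of growth and higher numbers for weaker inhibition of growth), compound 1 `CN1CCN(C(=O)/C=C/c2ccncc2-c2ccc3ccccc3c2)CC1` reaches only a limit, > 10000 nM as reported. For the measured compounds named here, compound 2 `CNC(=O)/C=C/c1ccncc1-c1ccc2ccccc2c1` gives 6620 nM as the only true number so far. Going by the values given here, compound 3 `NNC(=O)CCc1ccncc1-c1ccc2ccccc2c1` carries 2-(aminocarbamoyl)ethyl in place of 2-(methylcarbamoyl)ethenyl on an aromatic carbon as its single change. Among the compounds with values here, the one measured step (an at least 1.5-fold lower number from compound 1 to compound 2 (0.17 log units; that floor lies within the scatter)) altered a different place, the group on the carbonyl carbon, so it offers little guidance and no direction here. No shift beyond the scatter is expected, and the expected change is a 1.1-fold higher number from compound 2 to compound 3 (0.02 log units; within the scatter) for now. Compound 3 is estimated at 7000 nM with an expected range from 2000 nM to 20000 nM in all.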

Compound 3, concentration for 50% growth inhibition: > 10000 nM
Compound 3: a limit, no number; the forecaster's own chance of this, stated with the estimate: 35%; at least 1.4-fold (0.15 log units) between middle value and limit.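

Until this point only the group on the carbonyl carbon had changed. Here the side chain on the aromatic carbon opposite the ring nitrogen changes, and this assay gives an at least 1.5-fold higher number from compound 2 to compound 3 (0.17 log units; that floor lies within the scatter). This swap brings no stronger inhibition of growth, but compound 3 ends at a limit rather than a number, so the true size of the step stays unknown: the limit of > 10000 nM in this assay, at which 2 of the 3 values shown sit.

The swap alters the chain's double bonds and its end group together, so the compounds shown cannot separate these two changes. From the compounds shown here alone, whether 2-(methylcarbamoyl)ethyl, a carboxylic acid or a longer chain at this place would lower the number also remains open.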